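This account rests on a few compounds, and the source may have more. Where it says the series, first, only, none or still open, it means among the compounds named here.

Among the measured compounds shown here, in a functional assay on HT-29 cells (Homo sapiens) for antiproliferative activity, read by sulforhodamine B assay, with a stated time of 72 h (on this read-out higher numbers stand for weaker inhibition and lower numbers for stronger inhibition), compound 1 (`COc1cccc(NC(=S)N/N=C/c2ccc3ccccc3n2)c1`) gives 82400 nM and compound 2 (`Cc1ccccc1NC(=S)N/N=C/c1ccc2ccccc2n1`) gives 42300 nM on the numbers so far. For the measured compounds named here, these two values lie within the scatter of each other, so compound 2 stands level with its only measured neighbour. Compound 3 (`COc1ccc(NC(=S)N/N=C/c2ccc3ccccc3n2)cc1`) differs from compound 2 by 4-methoxyphenyl in place of 2-methylphenyl on an amide-type nitrogen in one place: 4-methoxyphenyl in place of 2-methylphenyl on an amide-type nitrogen. Going by the values given here, the one measured step at that nitrogen, a 1.9-fold lower number from compound 1 to compound 2 (0.29 log units; within the scatter) with 2-methylphenyl in place of 3-methoxyphenyl, stayed within the scatter. On that single step, no change beyond the scatter is expected in this assay and no direction can be called. An estimated 1.4-fold higher number from compound 2 to compound 3 (0.15 log units; within the scatter) is the working expectation. For compound 3 the estimated value is 60000 nM with an expected range of 25000 nM to 140000 nM for this read-out.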

Compound 3, half-maximal inhibitory concentration: 82300 nM
For compound 3 the middle estimate is 1.4-fold (0.14 log units) below the measured one; low and high end bracket the measured number.
By their numbers in this assay, from the lowest: compounds 2, 3 and 1 (each within the scatter of the next).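

In this assay, 4-methoxyphenyl in place of 2-methylphenyl on the amide-type nitrogen gives a 1.9-fold higher number from compound 2 to compound 3 (0.29 log units; within the scatter) and so adds a second step at this position that stays within the scatter. The step of a 1.0-fold lower number from compound 1 to compound 3 (0.00 log units; within the scatter), with 4-methoxyphenyl in place of 3-methoxyphenyl, shows that the two methoxyphenyl isomers read alike here, and all three substituted phenyl groups now stand level on this nitrogen. No measurement at hand offers an explanation for this flat reading.

The compounds shown leave open whether any group on this nitrogen can move the number beyond the scatter, for example a phenyl ring carrying an amine or a carboxylic acid, or a longer alkyl chain in place of the ring. They also leave open how much changes elsewhere on the shared core would matter.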